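The compounds below may be only part of what the source reports. "The series", "measured", "known", "first", "only" and "open" are said of these compounds alone.

In a functional assay on MGC-803 cells (Homo sapiens) for antiproliferative activity, read by MTT assay, with a stated time of 48 h (on this read-out lower numbers stand for stronger inhibition and higher numbers for weaker inhibition), the measured compounds read as follows.

Compound 1 `COc1ccc(CN(C(=O)CSc2ccccn2)c2cc(OC)c(OC)c(OC)c2)cc1` gives 2410 nM
Compound 2 `COc1ccc(CN(C(=O)CCCSc2nc3ccccc3o2)c2cc(OC)c(OC)c(OC)c2)cc1` gives 1290 nM
Compound 3 `COc1ccc(CN(C(=O)CSc2nnnn2C)c2cc(OC)c(OC)c(OC)c2)cc1` gives 2490 nM

Compound 3 has no clear place of its own among these values, since all three lie within the scatter of one another. The two steps that reach it are a 1.0-fold higher number from compound 1 to compound 3 (0.01 log units; within the scatter) and a 1.9-fold higher number from compound 2 to compound 3 (0.29 log units; within the scatter). The remaining step is a 1.9-fold lower number from compound 1 to compound 2 (0.27 log units; within the scatter).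

The next compound, compound 4 `COc1ccc(CN(C(=O)CSc2nc3ccccc3[nH]2)c2cc(OC)c(OC)c(OC)c2)cc1`, keeps the core of compound 3 and changes only the group on the sulfur: 1H-benzimidazol-2-yl in place of 1-methyl-1H-tetrazol-5-yl on a sulfur. Thus 1H-benzimidazol-2-yl stands in place of 1-methyl-1H-tetrazol-5-yl on a sulfur.

Among the measured compounds shown here, two measured steps bear on this change. The first, a 1.0-fold higher number from compound 1 to compound 3 (0.01 log units; within the scatter), exchanged one group for another on that same sulfur and left the number practically unchanged. The second, a 1.9-fold higher number from compound 2 to compound 3 (0.29 log units; within the scatter), is a less direct guide, as it also alters the chain, but it connects compound 3 to the 1,3-benzoxazol-2-yl group of compound 2. Neither step goes beyond the scatter, so no step beyond the scatter is expected in this assay.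

The estimate corresponds to a 1.5-fold lower number from compound 3 to compound 4 (0.17 log units; within the scatter), an expected change that stays within the scatter. For compound 4 the expected value is 1700 nM, with an estimated range from 600 nM to 4500 nM.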

Compound 4, half-maximal inhibitory concentration: 1230 nM
Compound 4: middle estimate off by 1.4-fold (0.14 log units), on the high side; the measured number falls inside the stated range.
By their numbers in this assay, from the lowest: compounds 4, 2, 1 and 3 (each within the scatter of the next, the first and the last beyond it).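

In this assay, among the compounds shown here, the group on the sulfur now yields the first step of this set to pass the scatter, since 1H-benzimidazol-2-yl in place of 1-methyl-1H-tetrazol-5-yl gives a 2.0-fold lower number from compound 3 to compound 4 (0.31 log units; beyond the scatter) and this step is modest in size. The same entering group does not separate itself from the other two groups, for it gives a 2.0-fold lower number from compound 1 to compound 4 (0.29 log units; within the scatter) against pyridin-2-yl and a 1.0-fold lower number from compound 2 to compound 4 (0.02 log units; within the scatter) against 2-((1,3-benzoxazol-2-yl)sulfanyl)ethyl, so the change registers only against the tetrazole and the pattern reaches no further than that single pair. Nothing available explains why this one exchange passes the scatter while the others do not.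

The compounds shown leave open how an amine or a carboxylic acid in place of 1H-benzimidazol-2-yl on a sulfur would read in this assay and whether the step would hold there. They also leave open how a longer chain on the carbonyl carbon would read with the (1H-benzimidazol-2-yl)sulfanyl group kept in place.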